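The source may report more compounds than this note shows. Statements on the series, on what has been measured and on what is new or still open speak of the compounds shown alone.

Compound 2 `O=C(O)c1ccc2noc(-c3ccc(-c4ccncc4)cc3)c2c1` gives 670 nM in an assay for inhibition of inositol hexakisphosphate kinase 3 (Homo sapiens), read by colorimetric assay, coupled enzyme assay and malachite green, with a stated time of 120 min, in the presence of a further agent that is not named here (a higher number here means a weaker inhibitor, a lower number a stronger inhibitor), the highest of the two numbers shown, while compound 1 `O=C(O)c1ccc2noc(-c3ccc(-c4cccnc4)cc3)c2c1` gives 610 nM, and the step of a 1.1-fold higher number from compound 1 to compound 2 (0.04 log units; within the scatter) is within the scatter. Compound 3 `O=C(O)c1ccc2noc(-c3ccc(N4CCCCC4)cc3)c2c1` differs from compound 2 by piperidin-1-yl in place of pyridin-4-yl on an aromatic carbon. Going by the values given here, the only measured step, from compound 1 to compound 2, swaps one aromatic position for another and was within the scatter, so it offers little guidance for a change to a non-aromatic ring. The step of a 1.2-fold higher number from compound 2 to compound 3 (0.08 log units; within the scatter) is therefore expected to stay within the scatter, with no clear direction. Compound 3 is estimated at 800 nM, in the range 250 nM to 2500 nM.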

Compound 3, half-maximal inhibitory concentration: 1790 nM
Estimate against measurement, compound 3: 2.2-fold (0.35 log units) below; the measured number falls inside the stated range.
By their numbers in this assay, from the lowest: compounds 1 and 2 (each within the scatter of the next); then compound 3.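

Unlike the swap between pyridin-3-yl and pyridin-4-yl, moving to the non-aromatic piperidin-1-yl in this assay gives a change beyond the scatter, with a 2.7-fold higher number from compound 2 to compound 3 (0.43 log units; beyond the scatter) and a 2.9-fold higher number from compound 1 to compound 3 (0.47 log units; beyond the scatter). Both steps are modest and run the same way, so at this position on the aromatic carbon, a six-membered ring with one nitrogen does not by itself preserve the number. Nothing available here accounts for the shift.

The compounds shown leave open how a phenyl ring, morpholin-4-yl or an open-chain amine would compare here. They also leave open whether the step would hold with an ester or amide in place of the carboxylic acid.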